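The source may report more compounds than this note shows. Statements on the series, on what has been measured and on what is new or still open speak of the compounds shown alone.

Compound 1 `CCn1c(-c2ccc(OCc3c(-c4c(Cl)cccc4Cl)noc3C(C)C)cc2)nc2ccc(C(=O)O)cc21` gives 5760 nM in an assay on HEK-293T cells for antagonist activity at vitamin D3 receptor (Homo sapiens), read by a luciferase reporter, with a stated time of 24 h; a lower number here means a stronger inhibitor, a higher number a weaker inhibitor.
Compound 2 `CC(C)c1onc(-c2c(Cl)cccc2Cl)c1COc1ccc(-c2nc3ccc(C(=O)O)cc3n2C2CC2)cc1` gives 3200 nM in this assay.
Compound 3 `CC(C)c1onc(-c2c(Cl)cccc2Cl)c1COc1ccc(-c2nc3ccc(C(=O)O)cc3n2CC2CC2)cc1` gives 2650 nM in this assay.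

Compound 3 carries the lowest of the three numbers, but its gap to compound 2, a 1.2-fold lower number from compound 2 to compound 3 (0.08 log units; within the scatter), lies within the scatter, so the two cannot be ranked against each other; only its gap to compound 1, a 2.2-fold lower number from compound 1 to compound 3 (0.34 log units; beyond the scatter), is beyond the scatter, and that step was modest. Compound 4 `CC(=O)N1CCC(n2c(-c3ccc(OCc4c(-c5c(Cl)cccc5Cl)noc4C(C)C)cc3)nc3ccc(C(=O)O)cc32)CC1` differs from compound 3 in one place: 1-acetylpiperidin-4-yl in place of cyclopropylmethyl on an aromatic nitrogen. All measured steps change the group on this same aromatic nitrogen, and none moved the number far, including a 1.8-fold lower number from compound 1 to compound 2 (0.26 log units; within the scatter). The new group is larger than any measured one, so the expected step of a 1.0-fold lower number from compound 3 to compound 4 (0.01 log units; within the scatter) is small, with no change beyond the scatter foreseen. Compound 4 is therefore estimated at 2600 nM, with a range from 900 nM to 7500 nM.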

Compound 4, half-maximal inhibitory concentration: > 10000 nM
Compound 4: no number, only a limit (the forecaster's own chance of this, stated with the estimate: 5%); middle value at least 3.8-fold (0.58 log units) away from the limit.
By their numbers in this assay, from the lowest: compounds 3, 2 and 1 (each within the scatter of the next, the first and the last beyond it). At a limit, above all of these: compound 4.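

In this assay, compound 4 stands at a limit of the assay, not at a number: the limit of > 10000 nM in this assay, at which 1 of the 4 values shown sits.

Within the data shown here, this aromatic nitrogen, where ethyl, cyclopropyl and cyclopropylmethyl gave no large steps, does not tolerate every group: 1-acetylpiperidin-4-yl brings an at least 3.7-fold higher number from compound 3 to compound 4 (0.57 log units; beyond the scatter) and an at least 3.1-fold higher number from compound 2 to compound 4 (0.49 log units; beyond the scatter). Against ethyl the change reads only as an at least 1.7-fold higher number from compound 1 to compound 4 (0.23 log units; that floor lies within the scatter), so that comparison alone shows no clear change.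

The compounds shown do not separate the effect of the piperidine ring from that of its acetyl group. A free piperidine amine or a plain cyclohexyl on this nitrogen would help to tell them apart.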